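The compounds below may be only part of what the source reports. "The series", "measured", "known", "first", "only" and "open" are said of these compounds alone.

Measured compounds:
Compound 1 `CC(=O)CC/C=C(\C)CCC1=C(C)CCCC1(C)C`: in a functional assay on UACC-257 cells (Homo sapiens) for inhibition (a lower number here means a stronger inhibitor of growth, a higher number a weaker inhibitor of growth), compound 1 gives > 15000 nM, a limit of the assay.
Compound 2 `C=C1CCCC(C)(C)C1CC[C@]1(C)CC[C@@H]([C@@H](C)C(=O)O)OO1`: compound 2 gives > 10000 nM, likewise a limit.
Compound 3 `C=C1CCCC(C)(C)C1(O)CC/C(C)=C/CC[C@]1(C)CC[C@@H]([C@@H](C)C(=O)OC)OO1`: compound 3 gives > 17500 nM, again a limit.

Every value here is a limit, so compound 2 cannot be ordered against the others; its limit of > 10000 nM in this assay, at which 1 of the 3 values shown sits, sits beside the limit of > 15000 nM in this assay, at which 1 of the 3 values shown sits, and (the limit of > 17500 nM in this assay, at which 1 of the 3 values shown sits). Among the compounds with values here, no two measured compounds differ in a single place, so no measured step is available.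

Compound 4 `C=C1CCCC(C)(C)C1CC[C@@]1(C)CC[C@H]([C@@H](C)C(=O)O)OO1` is a stereoisomer of compound 2: the two compounds have the same atoms and bonds; at least one stereo element is drawn with a configuration in one of them and without one in the other: 2 of 4 stereo elements differ; a stereocentre at a saturated ring carbon is drawn R in compound 2 and S in compound 4; a stereocentre at a saturated ring carbon is drawn S in compound 2 and R in compound 4. With no resolved number in this assay, no step beyond the scatter is expected, and a further limit is the likelier outcome. Compound 4 is expected at 15000 nM (range 5000 nM to 50000 nM). The expected step is a step that the limit leaves unreadable from compound 2 to compound 4.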

Compound 4, concentration for 50% growth inhibition: > 12500 nM
Compound 4: no number, only a limit; the forecaster's own chance of this, stated with the estimate: 85%; the middle value does not contradict the limit.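

In this assay compound 2 gives > 10000 nM, a limit. Within the data shown here, compound 4 gives > 12500 nM, also a limit, so no step between these two stereoisomers can be read. The compounds shown leave open whether the configuration at the two saturated ring carbons changes growth inhibition at all.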